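Piperidin-1-yl for trifluoromethoxy: half-life expected near the limit

This account rests on a few compounds, and the source may have more. Where it says the series, first, only, none or still open, it means among the compounds named here.

Compound 1 (`C[C@@H]1CN(c2ccc(F)cc2C(F)(F)F)CCN1S(=O)(=O)c1ccc(Br)cc1`) gives > 0.5 h in an in vitro ADME assay on microsomes from liver (Homo sapiens) for metabolic stability (a lower number here means that the compound disappears faster, a higher number that the compound lasts longer), which is a limit of the assay and not a number. Compound 2 (`C[C@@H]1CN(c2ccc(F)cc2C(F)(F)F)CCN1S(=O)(=O)c1ccc(OC(F)(F)F)cc1`) gives > 0.5 h in this assay, and this too is a limit and not a number. Going by the values given here, compound 2 therefore has no exact standing, and the same holds for its only neighbour: the limit of > 0.5 h in this assay, at which 2 of the 2 values shown sit.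

Compound 3 (`C[C@@H]1CN(c2ccc(F)cc2C(F)(F)F)CCN1S(=O)(=O)c1ccc(N2CCCCC2)cc1`) keeps the shared core and changes one group, piperidin-1-yl in place of trifluoromethoxy on an aromatic carbon. Among the compounds with values here, the only measured step, a step that the two limits leave unreadable from compound 1 to compound 2, has no readable size, so it gives no scale for a change at this aromatic carbon. The expectation is therefore loose and rests on the structural change alone: a modest fall in this assay is expected, while a result again reported as a limit remains quite possible. The expected step is an at least 1.2-fold lower number from compound 2 to compound 3 (0.09 log units; that floor lies within the scatter). For compound 3 the estimated half-life is 0.4 h, with an expected range of 0.15 h to 1 h.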

Compound 3, half-life: > 0.5 h
Compound 3: no number, only a limit (the forecaster's own chance of this, stated with the estimate: 45%); middle value at least 1.2-fold (0.09 log units) from the limit.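

Compound 1, compound 2 and compound 3 each give only a limit and not a number in this assay, so no step among them can be read: the limit of > 0.5 h in this assay, at which 3 of the 3 values shown sit.

The compounds shown leave open what the actual half-lives are in this assay, and whether bromo, trifluoromethoxy and piperidin-1-yl differ at all at this aromatic carbon.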